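Swapping the aryl on the hydrazone carbon: compound 3

The source may report more compounds than this note shows. Statements on the series, on what has been measured and on what is new or still open speak of the compounds shown alone.

Compound 2 `CN(C)CCn1cnnc1-c1cc(Oc2ccc(NC(=O)N/N=C/c3c[nH]c4ccccc34)cc2F)ccn1` gives 790 nM in a functional assay on MKN-45 cells (Homo sapiens) for cytotoxicity, read by MTT assay, with a stated time of 72 h (on this read-out higher numbers stand for weaker inhibition and lower numbers for stronger inhibition), and stands alongside compound 1 `CN(C)CCn1cnnc1-c1cc(Oc2ccc(NC(=O)N/N=C/c3ccc(Cl)cc3Cl)cc2F)ccn1`, which gives 750 nM, the two numbers lying within the scatter of each other. The change to compound 3 `COc1ccc(OC)c(/C=N/NC(=O)Nc2ccc(Oc3ccnc(-c4nncn4CCN(C)C)c3)c(F)c2)c1` is 2,5-dimethoxyphenyl in place of 1H-indol-3-yl on a carbon with a double bond to nitrogen. For the measured compounds named here, the one measured step on the same carbon with a double bond to nitrogen, a 1.1-fold higher number from compound 1 to compound 2 (0.02 log units; within the scatter), was within the scatter, so compound 3 is expected to show no step beyond the scatter, a 1.0-fold higher number from compound 2 to compound 3 (0.01 log units; within the scatter). Compound 3 is therefore estimated at 800 nM, with a range from 400 nM to 1600 nM.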

Compound 3, half-maximal inhibitory concentration: 1510 nM
The estimate for compound 3 lay 1.9-fold (0.28 log units) below the measured number; low and high end bracket the measured number.
By their numbers in this assay, from the lowest: compounds 1, 2 and 3 (each within the scatter of the next).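

In this assay, the carbon with a double bond to nitrogen now carries a third aryl group with no step beyond the scatter, with a 1.9-fold higher number from compound 2 to compound 3 (0.28 log units; within the scatter) and with a 2.0-fold higher number from compound 1 to compound 3 (0.30 log units; within the scatter) as well. The change from 1H-indol-3-yl removes a hydrogen-bond donor and brings in hydrogen-bond acceptors, and even this stays within the scatter. Nothing given here accounts for these numbers. Still open, on these data alone, is whether a non-aromatic group such as cyclohexyl, or an aryl group bearing a carboxylic acid or an amine, would move the number beyond the scatter.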